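Replacing 3-carbamoylphenyl with 2-chlorophenyl: an expected outcome

The source may hold more compounds than are shown below. What is called first, only, known or untested is meant among the compounds shown, and "the series" means these compounds.

In a functional assay on HL-60 cells (Homo sapiens) for inhibition, read by MTT assay, with a stated time of 72 h (on this read-out lower numbers stand for stronger inhibition and higher numbers for weaker inhibition), compound 1 (`Cc1nc(-c2ccccc2)c(C(=O)N2CCN(c3cccc(Cl)c3)CC2)o1`) gives 39.2 nM, compound 2 (`Cc1nc(-c2ccccc2)c(C(=O)N2CCN(c3cccc(C(N)=O)c3)CC2)o1`) gives 71 nM and compound 3 (`Cc1nc(-c2ccccc2Cl)c(C(=O)N2CCN(c3cccc(Cl)c3)CC2)o1`) gives 132 nM. The value of compound 2 therefore lies within the usual scatter of both others, although those two are further apart.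

Compound 4 (`Cc1nc(-c2ccccc2)c(C(=O)N2CCN(c3ccccc3Cl)CC2)o1`) has not yet been measured. It differs from compound 2 by 2-chlorophenyl in place of 3-carbamoylphenyl on an amine nitrogen in a ring.

Among the measured compounds shown here, two measured steps bear on this. The exchange of chloro for carbamoyl gave a 1.8-fold higher number from compound 1 to compound 2 (0.26 log units; within the scatter), so that group exchange alone suggests little change. The added chloro gave a 3.4-fold higher number from compound 1 to compound 3 (0.53 log units; beyond the scatter), a modest step at a different site, which leaves some room for movement. For the measured compounds named here, no measured compound tests the chloro placement in 2-chlorophenyl, so no shift beyond the scatter is expected, and the range is kept wide.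

The estimate means a 1.1-fold higher number from compound 2 to compound 4 (0.05 log units; within the scatter), an expected step in either direction. Compound 4 is expected at 80 nM, with an estimated range from 25 nM to 250 nM.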

Compound 4, half-maximal inhibitory concentration: 124 nM
The estimate for compound 4 lay 1.6-fold (0.19 log units) below the measured number; the measured number falls inside the stated range.
By their numbers in this assay, from the lowest: compounds 1, 2, 4 and 3 (each within the scatter of the next, the first and the last beyond it).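

In this assay, the placement of the chloro on this ring now has a direct test: 2-chlorophenyl in place of 3-chlorophenyl on the amine nitrogen gives a 3.2-fold higher number from compound 1 to compound 4 (0.50 log units; beyond the scatter), a modest step. The exchange of 3-carbamoylphenyl for 2-chlorophenyl gives a 1.7-fold higher number from compound 2 to compound 4 (0.24 log units; within the scatter), so these two groups cannot be told apart in this assay, even though they differ in both their substituent and its placement. At this position, then, moving the chloro produced a step beyond the scatter, whereas replacing it with carbamoyl did not, although this rests on a single pair for each change.

Nothing available accounts for the effect of moving the chloro. On these data alone, it remains open whether an amine or a carboxylic acid in place of the chloro of 3-chlorophenyl would stay within the scatter of compound 1.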